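This account rests on a few compounds, and the source may have more. Where it says the series, first, only, none or still open, it means among the compounds named here.

In a functional assay, read by Griess assay, with a stated time of 2.5 h (on this read-out lower numbers stand for stronger inhibition and higher numbers for weaker inhibition), the measured compounds give these values
Compound 1 `COc1cc(OC)c(OC)cc1/C=C/C(=O)c1ccccc1` gives 2.01 ug/mL
Compound 2 `COc1cc(OC)c(OC)cc1/C=C/C(=O)c1ccc(Cl)c([N+](=O)[O-])c1` gives 1.99 ug/mL
Compound 3 `COc1cc(OC)c(OC)cc1/C=C/C(=O)c1cccc(C(F)(F)F)c1` gives 2.09 ug/mL

These three values lie within the usual scatter of one another, so compound 3, at 2.09 ug/mL, stands level with the other two and not apart from them. The next structure is compound 4 `COc1cc(OC)c(OC)cc1/C=C/C(=O)c1cccc([N+](=O)[O-])c1`, which keeps the shared core and carries one change, nitro in place of trifluoromethyl on an aromatic carbon, counted as nitro in place of trifluoromethyl on an aromatic carbon in full. Within the data shown here, one measured step bears on this place: a 1.0-fold higher number from compound 1 to compound 3 (0.02 log units; within the scatter), so putting trifluoromethyl where hydrogen stood moved the number no further than the scatter. Compound 2 already carries a nitro group and gives 1.99 ug/mL without leaving the group of values. No change beyond the scatter is therefore expected in this assay. The estimated step is a 1.0-fold lower number from compound 3 to compound 4 (0.02 log units; within the scatter) and it is expected to stay within the scatter. For compound 4 the estimate is 2 ug/mL as the expected value, with an expected range from 1.2 ug/mL to 3.3 ug/mL for repeated measurements.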

Compound 4, half-maximal inhibitory concentration: 2.35 ug/mL
Compound 4: middle estimate off by 1.2-fold (0.07 log units), on the low side; the range from low to high includes it.
By their numbers in this assay, from the lowest: compounds 2, 1, 3 and 4 (each within the scatter of the next).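

In this assay nitro and trifluoromethyl on this aromatic carbon cannot be told apart (a 1.1-fold higher number from compound 3 to compound 4 (0.05 log units; within the scatter)). Nitro also stays level with plain hydrogen at this place (a 1.2-fold higher number from compound 1 to compound 4 (0.07 log units; within the scatter)), and hydrogen in place of the chloro group of compound 2 leaves the number within the scatter as well (a 1.2-fold higher number from compound 2 to compound 4 (0.07 log units; within the scatter)). So hydrogen, trifluoromethyl and nitro all sit here without separating, and nothing available explains this flat result.

On these data alone, whether an amine, a carboxylic acid or a longer chain at this place would move the number beyond the scatter remains open. Until some group does so, these compounds cannot show whether the number depends on what sits at this position.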